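From 2-methoxyethyl to 2-(oxan-4-yl)ethyl on the shared core

The source may report more compounds than this note shows. Statements on the series, on what has been measured and on what is new or still open speak of the compounds shown alone.

Within the data shown here, in an ADME assay on Caco-2 cells (Homo sapiens) for permeability, in the apical to basolateral direction (a lower number here means that the compound crosses the layer more slowly, a higher number that the compound crosses the layer faster), compound 1 (`Cc1nc(-c2nc[nH]n2)ccc1-c1cnc2c(n1)N([C@H]1CC[C@@H](O)CC1)C(=O)CN2`) gives 1.6 10^-6 cm/s and compound 2 (`COCCN1C(=O)CNc2ncc(-c3ccc(-c4nc[nH]n4)nc3C)nc21`) gives 5 10^-6 cm/s as the higher of the two numbers so far. Compound 3 (`Cc1nc(-c2nc[nH]n2)ccc1-c1cnc2c(n1)N(CCC1CCOCC1)C(=O)CN2`) is still unmeasured. It differs from compound 2 by one change (oxan-4-yl in place of methoxy on a saturated chain carbon, two bonds along the chain from an amide-type nitrogen in a ring): oxan-4-yl in place of methoxy on a saturated chain carbon, two bonds along the chain from an amide-type nitrogen in a ring. Among the measured compounds shown here, only one measured step bears on this, made on that same nitrogen: a 3.1-fold higher number from compound 1 to compound 2 (0.49 log units; beyond the scatter) with 2-methoxyethyl in place of 4-hydroxycyclohexyl, modest but beyond the scatter. For the measured compounds named here, no measured compound carries oxan-4-yl, so that step gives no firm direction. In this assay the expected step is a 1.3-fold lower number from compound 2 to compound 3 (0.10 log units; within the scatter) and thus none beyond the scatter. Compound 3 is estimated at 4 10^-6 cm/s (expected range 1.5 10^-6 cm/s to 10 10^-6 cm/s).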

Compound 3, apparent permeability: 4.2 10^-6 cm/s
Estimate against measurement, compound 3: 1.1-fold (0.02 log units) below; the measured number falls inside the stated range.
By their numbers in this assay, from the lowest: compound 1; then compounds 3 and 2 (each within the scatter of the next).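

On the amide-type nitrogen of the shared core, a much larger group at the end of the chain, oxan-4-yl with its six heavy atoms in place of the two of methoxy, stays within the scatter in this assay (a 1.2-fold lower number from compound 2 to compound 3 (0.08 log units; within the scatter)). The second chain-bearing group also stands apart from 4-hydroxycyclohexyl (a 2.6-fold higher number from compound 1 to compound 3 (0.42 log units; beyond the scatter)), so among these three compounds both 2-methoxyethyl and 2-(oxan-4-yl)ethyl give numbers beyond the scatter from compound 1, and none goes against this. No measurement shown gives a reason for either result.

The compounds shown leave open whether this level holds for a different end group on the chain, such as an amine or a carboxylic acid, or for a longer chain. They also do not separate the hydroxy group of 4-hydroxycyclohexyl from the rest of that group, so the steps from compound 1 cannot be assigned to either part.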